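A few compounds are considered here, and "the series" means these few. Any claim that something is new, unique, unknown or untested is made for them only; others in the source may bear on it.

For the measured compounds named here, compound 1 `O=C(NO)c1ccc(NCc2nc(-c3ccc(Cl)cc3)nn2-c2ccccc2)cc1` gives 67.2% in an assay on Sf9 cells for inhibition of protein deacetylase HDAC6 (Homo sapiens), read by fluorescence, with a stated time of 40 min, tested at 100 nM (on this read-out lower numbers stand for less inhibition and higher numbers for more inhibition at the one concentration tested (going by the name of the read-out)), the highest of the two numbers measured so far; compound 2 `Nc1ccccc1NC(=O)c1ccc(NCc2nc(-c3ccccc3)nn2-c2ccccc2)cc1` gives 5% in this assay, a gap beyond the usual scatter. Compound 3 `O=C(NO)c1ccc(NCc2nc(-c3ccccn3)nn2-c2ccccc2)cc1` has not been measured yet. It differs from compound 1 by pyridin-2-yl in place of 4-chlorophenyl on an aromatic carbon, the rest of the structure being unchanged. Going by the values given here, no measured pair shows this change, so its effect rests on expectation alone. The step of a number 12.2 percentage points lower from compound 1 to compound 3 (beyond the scatter) is expected to be a modest fall, at or somewhat beyond the scatter. For compound 3 the estimate is 55%, with a range from 30% to 78%.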

Compound 3, a percentage reported as inhibition, at one concentration (the size of the read-out at that concentration, not a potency): 58.6%
Compound 3: the middle estimate sits 3.6 percentage points below what was measured; the range from low to high includes it.
By their numbers in this assay, from the lowest: compound 2; then compounds 3 and 1 (each within the scatter of the next).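

Pyridin-2-yl in place of 4-chlorophenyl gives a number 8.6 percentage points lower from compound 1 to compound 3 (within the scatter) in this assay, so at this aromatic carbon an aromatic ring with a ring nitrogen and no chlorine cannot be told apart from the chlorinated ring on this read-out. For the compounds shown here, this is the first step at this position, as compound 1 and compound 2 differ in more than one place. No measured property bears on this step. Open, from the compounds shown here alone, are the pyridin-3-yl and pyridin-4-yl isomers and non-aromatic groups here, such as an amine, a carboxylic acid or a short alkyl chain. A single-concentration read-out also leaves open whether compound 1 and compound 3 match in potency.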